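A few compounds are considered here, and "the series" means these few. Any claim that something is new, unique, unknown or untested is made for them only; others in the source may bear on it.

Measured in a functional assay on A549 cells (Homo sapiens) for inhibition, read by CCK-8 assay, with a stated time of 48 h; a higher number here means a weaker inhibitor, a lower number a stronger inhibitor:
- Compound 1 `COc1cc(-c2cc3nccc(-c4cc(OC)c(OC)c(OC)c4)n3n2)cc(OC)c1OC`: > 10000 nM
- Compound 2 `Cn1ccc2cc(-c3cc4nccc(-c5ccc(F)cc5)n4n3)ccc21`: 3520 nM
- Compound 3 `COc1cc(-c2ccnc3cc(-c4ccccc4)nn23)cc(OC)c1OC`: 208 nM

The entry for compound 1 is a limit of the assay, not a number. Of the two true numbers, compound 3 has the lower, and its gap to compound 2 lies beyond the scatter, so compound 3 is the stronger of that pair. Compound 4 `COc1cc(-c2ccnc3cc(-c4ccc(C(C)=O)cc4)nn23)cc(OC)c1OC` turns the phenyl of compound 3 into 4-acetylphenyl, with acetyl in place of hydrogen on an aromatic carbon. Within the data shown here, no two measured compounds differ in one place only, so the expectation starts from compound 3 at 208 nM. A modest loss of strength is expected in this assay, estimated as a 1.9-fold higher number from compound 3 to compound 4 (0.28 log units; within the scatter). Compound 4 is estimated at 400 nM, within a range of 90 nM to 3000 nM.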

Compound 4, half-maximal inhibitory concentration: 4100 nM
Compound 4: middle estimate off by 10-fold (1.01 log units), on the low side; measured number outside the range, above it.
By their numbers in this assay, from the lowest: compound 3; then compounds 2 and 4 (each within the scatter of the next). At a limit, above all of these: compound 1.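

In this assay the place on the phenyl of compound 3 proves sensitive to change: acetyl in place of hydrogen, on an aromatic carbon para to a large group, gives a 20-fold higher number from compound 3 to compound 4 (1.29 log units; beyond the scatter) as a large loss of strength. Among these compounds, no earlier pair differed in one place, so this is the first direct reading of any single change. Both ends of this step are true numbers, and only compound 1 stands at a limit: the limit of > 10000 nM in this assay, at which 1 of the 4 values shown sits.

On these data alone, whether the loss belongs to acetyl itself or would follow any group at this place stays open. A methoxy, an amine or a carboxylic acid at the same carbon would help to separate the two.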